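Chloro to Fluoro Exchange on Two Related Cores

The compounds below may be only part of what the source reports. "The series", "measured", "known", "first", "only" and "open" are said of these compounds alone.

Compound 1, `Fc1ccc2nc(NC(=S)Nc3ccc(Cl)cc3)sc2c1`, gives 31200 nM in a functional assay on THP-1 cells (Homo sapiens) for cytotoxicity, read by MTT assay, with a stated time of 48 h; on this read-out higher numbers stand for weaker inhibition and lower numbers for stronger inhibition.
Compound 2, `Fc1ccc(NC(=S)Nc2nc3ccc(F)cc3s2)cc1`, gives 34600 nM in this assay.
Compound 3, `Fc1ccc2nc(Nc3nc4ccc(Cl)cc4s3)sc2c1`, gives 41000 nM in this assay.

The three measured compounds fall close together, and none of the gaps between them reaches beyond the usual scatter, so no order among them can be claimed. Compound 1 and compound 2 share one core and differ by a single change, (fluoro in place of chloro on an aromatic carbon). That change gave a 1.1-fold higher number from compound 1 to compound 2 (0.04 log units; within the scatter), a step that is within the scatter and therefore cannot be distinguished from no change at all.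

Compound 3 carries a different core; the difference between the two cores is not broken down here. Compound 4, `Fc1ccc2nc(Nc3nc4ccc(F)cc4s3)sc2c1`, is not yet measured and differs from compound 3 by fluoro in place of chloro on an aromatic carbon. For the measured compounds named here, this is the same kind of change as the one from compound 1 to compound 2, but not the same: in compound 1 the chloro sits on a six-membered aromatic ring of carbon only, para to a large group, whereas in compound 3 it sits on such a ring that is part of a fused or bridged system of two rings, meta to a fused ring and para to a fused ring.

For compound 4 the expected step is a 1.1-fold higher number from compound 3 to compound 4 (0.04 log units; within the scatter), essentially flat, because the earlier change gave a 1.1-fold higher number from compound 1 to compound 2 (0.04 log units; within the scatter). Compound 4 is therefore expected to show about 45000 nM in this assay, with a plausible range from 20000 nM to 100000 nM.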

Compound 4, half-maximal inhibitory concentration: 17500 nM
Beside the measured number, compound 4's estimate is 2.6-fold (0.41 log units) above it; measured number below the stated range.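

In this assay, putting fluoro in place of chloro on the core of compound 3 gave a 2.3-fold lower number from compound 3 to compound 4 (0.37 log units; beyond the scatter), a modest step towards stronger inhibition that lies beyond the usual scatter, whereas the same exchange on the other core gave a 1.1-fold higher number from compound 1 to compound 2 (0.04 log units; within the scatter), which cannot be told apart from no change. Seen side by side, the two results look different, yet the gap between them is too small to count as a real difference between the cores: the same change on two cores in this assay, a 1.1-fold higher number (0.04 log units; within the scatter) from compound 1 to compound 2 and a 2.3-fold lower number (0.37 log units; beyond the scatter) from compound 3 to compound 4, 2.6-fold (0.41 log units) apart, within the scatter of two such steps. This shows that the exchange did not weaken inhibition on either core, but it does not show that the gain on the core of compound 3 is special to that core, nor that the same gain would carry over to the other one, and two pairs are too few to settle either point.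

On these data alone, it remains open how a bromo, a methoxy or an amine on the same aromatic carbon would compare with chloro and fluoro on these cores. As far as these compounds go, it also remains open whether the exchange would give a flat step or a modest gain on a third core.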